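Anilide variation on a trifluoromethyl ketone hydrate chain

This account rests on a few compounds, and the source may have more. Where it says the series, first, only, none or still open, it means among the compounds named here.

Measured compounds: compound 1 `COc1ccccc1NC(=O)CCCCCCNC(=O)C(O)(O)C(F)(F)F` gives 10100 nM; compound 2 `O=C(CCCCCCNC(=O)C(O)(O)C(F)(F)F)Nc1ccc(Cl)cc1` gives 4230 nM; compound 3 `O=C(CCCCCCNC(=O)C(O)(O)C(F)(F)F)Nc1c(F)cc(F)cc1F` gives 22200 nM, all in a functional assay on HCT-116 cells (Homo sapiens) for inhibition, read by colorimetric assay, with a stated time of 3 days; a lower number here means a stronger inhibitor, a higher number a weaker inhibitor.

Compound 3 has the highest number of the three; its nearest neighbour is compound 1, with a 2.2-fold higher number from compound 1 to compound 3 (0.34 log units; beyond the scatter), and furthest is compound 2, with a 5.2-fold higher number from compound 2 to compound 3 (0.72 log units; beyond the scatter). Compound 4 `O=C(CCCCCCNC(=O)C(O)(O)C(F)(F)F)Nc1ccccc1Br` differs from compound 3 by 2-bromophenyl in place of 2,4,6-trifluorophenyl on an amide-type nitrogen. For the measured compounds named here, the steps that bear on this are a 5.2-fold higher number from compound 2 to compound 3 (0.72 log units; beyond the scatter) and a 2.2-fold higher number from compound 1 to compound 3 (0.34 log units; beyond the scatter), both modest and both pointing to a lower number once the 2,4,6-trifluorophenyl is replaced. A modest step toward a lower number is therefore expected, a 3.2-fold lower number from compound 3 to compound 4 (0.50 log units; beyond the scatter). Compound 4 is estimated at 7000 nM, ranging from 2500 nM to 20000 nM.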

Compound 4, half-maximal inhibitory concentration: 14500 nM
Compound 4: the middle estimate sits 2.1-fold (0.32 log units) below what was measured; the measured number falls inside the stated range.
By their numbers in this assay, from the lowest: compound 2; then compounds 1, 4 and 3 (each within the scatter of the next, the first and the last beyond it).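

In this assay, 2-bromophenyl on the amide-type nitrogen cannot be told apart from 2,4,6-trifluorophenyl (a 1.5-fold lower number from compound 3 to compound 4 (0.18 log units; within the scatter)), nor, with bromo in place of methoxy on an aromatic carbon, from compound 1 (a 1.4-fold higher number from compound 1 to compound 4 (0.16 log units; within the scatter)), although compounds 1 and 3 themselves lie beyond the scatter of each other. The 4-chlorophenyl of compound 2 stays apart from the new group (a 3.4-fold higher number from compound 2 to compound 4 (0.54 log units; beyond the scatter)). No evidence shown accounts for these differences.

The halogen and its place on the ring both change between compounds 2 and 4, and the compounds shown do not separate the two. As far as these compounds go, how an amine or a carboxylic acid on that ring would read also stays open.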